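From a Propylamino to a Benzylamino Analogue

A few compounds are considered here, and "the series" means these few. Any claim that something is new, unique, unknown or untested is made for them only; others in the source may bear on it.

Compound 1 `CNc1ccc2nc(-c3c(Cl)nc(N)nc3N[C@@H]3C[C@H](CO)[C@@H](O)[C@H]3O)sc2c1`: 6000 nM
Compound 2 `CCCNc1nc(C)c(-c2nc3ccccc3s2)c(N[C@@H]2C[C@H](CO)[C@@H](O)[C@H]2O)n1`: > 25000 nM

In an ADME assay on cells (Homo sapiens) for cytotoxicity, read by polymerase chain reaction, with a stated time of 3 days (on this read-out higher numbers stand for lower toxicity in this test and lower numbers for higher toxicity in this test), compound 1 gives 6000 nM. Compound 2 gives only a limit, > 25000 nM, so its true value is not known (the limit of > 25000 nM in this assay, at which 1 of the 2 values shown sits). Compound 3 `Cc1nc(NCc2ccccc2)nc(N[C@@H]2C[C@H](CO)[C@@H](O)[C@H]2O)c1-c1nc2ccccc2s1` differs from compound 2 in one place, (phenyl in place of ethyl on a saturated chain carbon bound to a nitrogen on an aromatic ring), which reads propyl to benzyl at the next bond out. Going by the values given here, no measured step is available to set the size of this change, so no shift beyond the usual scatter is expected; compound 3 is expected to sit near the same limit, with the step of a number no higher from compound 2 to compound 3 (the limit leaves the size open). Compound 3 is thus estimated at 25000 nM, ranging from 9000 nM to 60000 nM.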

Compound 3, half-maximal cytotoxic concentration: 9000 nM
Compound 3: the middle estimate sits 2.8-fold (0.44 log units) above what was measured; low and high end bracket the measured number.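

In this assay, benzylamino in place of propylamino brings an at least 2.7-fold lower number from compound 2 to compound 3 (0.44 log units; beyond the scatter) and so shows that this place can move the read-out, towards higher toxicity in this test. For compound 2 the value > 25000 nM is a limit, so the full size of this step stays unknown: the limit of > 25000 nM in this assay, at which 1 of the 3 values shown sits.

The compounds shown leave open whether a saturated ring, as in cyclohexylmethylamino, or a longer chain, as in pentylamino, would give the same lower number at this place. They also leave open whether the change would carry over to the core of compound 1.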